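Aryl swap on the hydrazone carbon: toward a hydroxyphenyl

The source may hold more compounds than are shown below. What is called first, only, known or untested is meant among the compounds shown, and "the series" means these compounds.

Going by the values given here, compound 2 `O=C(N/N=C/c1cccc(Br)c1)Nc1cc2c(Nc3ccc(F)c(Cl)c3)ncnc2cc1O[C@H]1CCOC1` gives the lowest of the two numbers so far in a functional assay on A549 cells (Homo sapiens) for cytotoxicity, read by MTT assay, with a stated time of 72 h (on this read-out higher numbers stand for weaker inhibition and lower numbers for stronger inhibition), at 10700 nM; compound 1 `O=C(N/N=C/c1ccc(F)cc1)Nc1cc2c(Nc3ccc(F)c(Cl)c3)ncnc2cc1O[C@H]1CCOC1` gives 35100 nM. Compound 3 `O=C(N/N=C/c1ccc(O)cc1)Nc1cc2c(Nc3ccc(F)c(Cl)c3)ncnc2cc1O[C@H]1CCOC1` differs from compound 2 by 4-hydroxyphenyl in place of 3-bromophenyl on a carbon with a double bond to nitrogen. Among the compounds with values here, the one step that bears on this change is a 3.3-fold lower number from compound 1 to compound 2 (0.52 log units; beyond the scatter), a modest move from exchanging the aryl group on the same carbon. A further exchange of that aryl group is therefore expected to move this assay by a comparably modest amount, and the expected step is a 2.3-fold higher number from compound 2 to compound 3 (0.37 log units; beyond the scatter), toward a higher number. Compound 3 is thus estimated at 25000 nM, within 8000 nM to 70000 nM.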

Compound 3, half-maximal inhibitory concentration: 1320 nM
Estimate against measurement, compound 3: 19-fold (1.28 log units) above; measured number outside the range, below it.
By their numbers in this assay, from the lowest: compound 3; then compound 2; then compound 1.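

At the aryl group on a carbon with a double bond to nitrogen, this assay spans a wider range than the first exchange showed (in this exchange, an 8.1-fold lower number from compound 2 to compound 3 (0.91 log units; beyond the scatter)). Going by these compounds alone, the clearest comparison is hydroxy in place of fluoro on an aromatic carbon, the only change in this pair (a 27-fold lower number from compound 1 to compound 3 (1.42 log units; beyond the scatter)). No measurement available here accounts for either step.

The compounds shown leave open whether the lower number follows the hydroxy group itself. 4-Methoxyphenyl or 4-aminophenyl on the same carbon would test this.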